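Removing the iodo group from a thiourea: expected tolerance

This account rests on a few compounds, and the source may have more. Where it says the series, first, only, none or still open, it means among the compounds named here.

Measured so far:
compound 1, `FC(F)(F)c1cccc(NC(=S)Nc2ccc(I)cc2)c1`, 9500 nM
compound 2, `Fc1ccc(NC(=S)Nc2cccc(C(F)(F)F)c2)cc1Cl`, 11000 nM

In an ADME assay on MDBK cells (Bos taurus) for cytotoxicity, read by MTT assay, with a stated time of 96 h (a lower number here means that less compound is tolerated, a higher number that more compound is tolerated), compound 1 gives 9500 nM. Compound 2 gives 11000 nM in this assay, and the two numbers lie within the usual scatter of each other, so neither compound can be said to be tolerated better than the other. Both share the trifluoromethylphenyl thiourea core, and the pair tells nothing about a single substituent change.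

Compound 3, `FC(F)(F)c1cccc(NC(=S)Nc2ccccc2)c1`, has not been measured in this assay. It differs from compound 1 in one place: hydrogen in place of iodo on an aromatic carbon. Among the measured compounds shown here, no measured pair shows what this change does here. The step from compound 1 to compound 3 is therefore expected to be small, most likely a modest rise in tolerated concentration or none beyond the scatter, estimated as a 1.6-fold higher number from compound 1 to compound 3 (0.20 log units; within the scatter). On that basis compound 3 is expected to give about 15000 nM in this assay, with a range from 6000 nM to 40000 nM.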

Compound 3, half-maximal cytotoxic concentration: 49000 nM
Compound 3: the middle estimate sits 3.3-fold (0.51 log units) below what was measured; the whole stated range lies below it.
By their numbers in this assay, from the lowest: compounds 1 and 2 (each within the scatter of the next); then compound 3.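

In this assay, among the compounds shown here, the replacement of iodo by hydrogen on an aromatic carbon, para to a large group, gives the first reading of a single change at this position: a 5.2-fold higher number from compound 1 to compound 3 (0.71 log units; beyond the scatter). The 4-iodophenyl to phenyl change is therefore not silent here, and the tolerated concentration depends on what occupies this position, at least in this pair. No available evidence explains the size of this step.

As far as these compounds go, whether a different group at this position, such as a bromo group, a methoxy group or an amine, would stay close to compound 1 or move toward compound 3 remains open. From the compounds shown here alone, it is also open whether the same replacement would give a similar step on a ring carrying further substituents, as the ring of compound 2 does.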